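The source may report more compounds than this note shows. Statements on the series, on what has been measured and on what is new or still open speak of the compounds shown alone.

Two members of the shared core carry a number in an assay for binding affinity to Corticotropin releasing factor receptor (Rattus norvegicus); a higher number here means a weaker inhibitor, a lower number a stronger inhibitor. Compound 1 `CCCC(C)n1c(CC)nc2c(-c3ccc(C(C)(C)O)cc3Cl)ccnc21` gives 24 nM, and compound 2 `CCCC(C)n1c(CC)nc2c(-c3ccc(OC)cc3C(F)(F)F)ccnc21` gives 0.74 nM. Compound 1 therefore stands at the higher of the two values, and its gap to compound 2 lies beyond the usual scatter of this assay.

Compound 3 `CCCC(C)n1c(CC)nc2c(-c3ccc(C(F)(F)F)cc3Cl)ccnc21` has not yet been measured in this assay. It differs from compound 1 in one place: trifluoromethyl in place of 1-hydroxy-1-methylethyl on an aromatic carbon. Within the data shown here, no measured pair covers this exchange, so the size of the step cannot be read off and can only be expected. Compound 2, which also carries a trifluoromethyl group on the aromatic ring, gives 0.74 nM, and this supports an expectation that compound 3 lands below compound 1. The expected step is a 4.8-fold lower number from compound 1 to compound 3 (0.68 log units; beyond the scatter). The estimate for compound 3 in this assay is 5 nM, with a range from 1 nM to 25 nM.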

Compound 3, inhibition constant: 1.1 nM
Compound 3: the middle estimate sits 4.5-fold (0.66 log units) above what was measured; measured number inside the range.
By their numbers in this assay, from the lowest: compounds 2 and 3 (each within the scatter of the next); then compound 1.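

At this position, para to a large group and meta to a chloro group, the exchange of 1-hydroxy-1-methylethyl for trifluoromethyl gives a large change in this assay: a 22-fold lower number from compound 1 to compound 3 (1.34 log units; beyond the scatter). The position is therefore sensitive to the group it carries, even though both groups count 4 heavy atoms; the exchange also removes the 1 hydrogen-bond donor and 1 hydrogen-bond acceptor of the leaving group. No measurement at hand explains the step or separates these differences.

Open, going by these compounds, is how a tert-butyl group, which keeps the carbon branching of 1-hydroxy-1-methylethyl without its oxygen, or a primary amine would read at this position with the chloro group kept. Also open, on these data alone, is whether the exchange gives a step of similar size with a nitrile in place of the chloro group.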